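The source may hold more compounds than are shown below. What is called first, only, known or untested is meant among the compounds shown, and "the series" means these compounds.

Series notes, variation on a carbonyl carbon of the shared core. The core is that of compound 1 `CCCC(=O)Nc1cccc(NC(=O)COc2ccc3c(=O)ccoc3c2)c1`, which in an assay on isolated protein for inhibition of Rho-associated protein kinase 1 (Homo sapiens), read by scintillation counting, radiometric assay and 33P incorporation, with a stated time of 40 min, in the presence of a further agent that is not named here (a higher number here means a weaker inhibitor, a lower number a stronger inhibitor), gives 1430 nM. Compound 2 `O=C(COc1ccc2c(=O)ccoc2c1)Nc1cccc(NC(=O)c2ccc([N+](=O)[O-])cc2)c1` gives 67 nM in this assay, and compound 3 `O=C(COc1ccc2c(=O)ccoc2c1)Nc1cccc(NC(=O)c2cnc(C(F)(F)F)s2)c1` gives 160 nM. Compound 3 stands second of the three numbers measured: it sits closest to compound 2, separated by a 2.4-fold higher number from compound 2 to compound 3 (0.38 log units; beyond the scatter), and furthest from compound 1, with an 8.9-fold lower number from compound 1 to compound 3 (0.95 log units; beyond the scatter). The unmeasured compound 4 `Nc1cccc(C(=O)Nc2cccc(NC(=O)COc3ccc4c(=O)ccoc4c3)c2)c1` differs from compound 3 by 3-aminophenyl in place of 2-(trifluoromethyl)-1,3-thiazol-5-yl on a carbonyl carbon.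

Two kinds of measured step bear on this change. Exchange of propyl for a ring on the same carbonyl carbon gave a 21-fold lower number from compound 1 to compound 2 (1.33 log units; beyond the scatter) and an 8.9-fold lower number from compound 1 to compound 3 (0.95 log units; beyond the scatter); the move between the two rings gave a 2.4-fold higher number from compound 2 to compound 3 (0.38 log units; beyond the scatter). Compound 4 carries a six-membered aromatic ring of carbon only, as compound 2 does, so the nearer reference is compound 2 rather than compound 1. Among the compounds with values here, no measured pair sets 3-aminophenyl against 4-nitrophenyl, so whether compound 4 lands where compound 2 does is open. The expected step is a 1.6-fold lower number from compound 3 to compound 4 (0.20 log units; within the scatter), a modest move towards a lower number. Compound 4 is therefore estimated at 100 nM in this assay, with a range from 35 nM to 350 nM.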

Compound 4, half-maximal inhibitory concentration: 670 nM
Beside the measured number, compound 4's estimate is 6.7-fold (0.83 log units) below it; measured number outside the range, above it.
By their numbers in this assay, from the lowest: compound 2; then compound 3; then compound 4; then compound 1.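

Replacing propyl with a ring on this carbonyl carbon does not by itself bring the large gain seen for compound 2: in this assay the 3-aminophenyl group gives only a 2.1-fold lower number from compound 1 to compound 4 (0.33 log units; beyond the scatter) and so stays much nearer the propyl amide than the other two rings do. A six-membered aromatic ring of carbon only is also not enough to match compound 2, since 3-aminophenyl in place of 4-nitrophenyl gives a 10-fold higher number from compound 2 to compound 4 (1.00 log units; beyond the scatter) in this series. Ring type alone therefore does not set the order, as the 2-(trifluoromethyl)-1,3-thiazol-5-yl group of compound 3 lies on the lower side of compound 4 with a 4.2-fold higher number from compound 3 to compound 4 (0.62 log units; beyond the scatter) yet on the higher side of compound 2.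

As far as these compounds go, whether the step from compound 2 to compound 4 follows from the change of nitro to amine or from the change of ring position stays open, and 3-nitrophenyl or 4-aminophenyl on this carbonyl carbon would separate the two. No measurement at hand accounts for any of these steps.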